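The compounds below may be only part of what the source reports. "The series", "measured", "known", "first", "only" and "open" are said of these compounds alone.

Measured so far:
Compound 1 `Cc1cnc(Nc2ccc(Cl)cc2)nc1Nc1nc2ccccc2s1` — in a functional assay on MCF7 cells (Homo sapiens) for antiproliferative activity, read by MTT assay, with a stated time of 48 h (a lower number here means a stronger inhibitor, a higher number a weaker inhibitor), compound 1 gives > 50000 nM, a limit of the assay rather than a number.
Compound 2 `Cc1ccc2nc(Nc3ccnc(Nc4ccc(S(C)(=O)=O)cc4)n3)sc2c1` — in this assay compound 2 gives > 50000 nM, again only a limit.
Compound 3 `CS(=O)(=O)c1ccc(Nc2ncc(F)c(Nc3nc4ccc(F)cc4s3)n2)cc1` — in this assay compound 3 gives > 50000 nM, also a limit.

Compound 1 therefore has no measured position within the working window of this assay: its value is a limit, and so are the other two shown, so that the limit of > 50000 nM in this assay, at which 3 of the 3 values shown sit, describes the whole set. For the measured compounds named here, no step between any two measured compounds can be drawn, and nothing within the set separates one compound from another.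

The unmeasured compound 4 `Cc1cnc(Nc2ccc(C(C)C)cc2)nc1Nc1nc2ccccc2s1` differs from compound 1 by isopropyl in place of chloro on an aromatic carbon. Going by the values given here, with every value sitting at the limit there is no measured step to lean on; the expectation is a step of no size beyond the scatter, which here means compound 4 is expected to stay at or near the limit. Compound 4 is expected at 50000 nM, within 10000 nM to 100000 nM. The step this estimate implies is a number no higher from compound 1 to compound 4 (the limit leaves the size open), an expectation and not a measurement.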

Compound 4, half-maximal inhibitory concentration: > 50000 nM
Compound 4 ended at the assay's limit; the forecaster's own chance of this, stated with the estimate: 70%; the middle value sits exactly at the limit.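

Compound 1 and compound 4 both sit at a limit of the assay in this assay, so no step can be read between them: the limit of > 50000 nM in this assay, at which 4 of the 4 values shown sit.

The compounds shown leave open which change to the shared core, if any, would give a measurable value in this assay.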